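This account rests on a few compounds, and the source may have more. Where it says the series, first, only, none or still open, it means among the compounds named here.

In a functional assay on Huh-7 cells (Homo sapiens) for antiproliferative activity, with a stated time of 48 h (a higher number here means a weaker inhibitor, a lower number a stronger inhibitor), compound 1 `CCOC(=O)c1ccc(-c2ccc(N(CC)CC)nn2)cc1` gives 9000 nM. Compound 2 `CCOC(=O)c1ccc(-c2ccc(N(C)C)nn2)cc1` reaches only a limit of this assay, > 25000 nM. Compound 3 `CCOC(=O)c1ccc(-c2ccc(OCC)nn2)cc1` likewise gives only a limit, > 25000 nM. Two of the three values thus sit at the limit of > 25000 nM in this assay, at which 2 of the 3 values shown sit. The measured steps show an at least 2.7-fold higher number from compound 1 to compound 2 (0.44 log units; beyond the scatter) and an at least 2.7-fold higher number from compound 1 to compound 3 (0.44 log units; beyond the scatter), while between compound 2 and compound 3 there is a step that the two limits leave unreadable from compound 2 to compound 3. Compound 4 `CCOC(=O)c1ccc(-c2ccc(OC(C)C)nn2)cc1` differs from compound 3 by methyl in place of hydrogen on a saturated chain carbon bound to an oxygen on an aromatic ring and a saturated chain carbon. Among the measured compounds shown here, no measured step alters an ethoxy group in this way, and the two readable steps both move away from diethylamino. Compound 3 stands at a limit, so the expected step that the limit leaves unreadable from compound 3 to compound 4 cannot be read from any measured pair. The estimate for compound 4 is 30000 nM, with a range from 8000 nM to 100000 nM.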

Compound 4, half-maximal inhibitory concentration: > 25000 nM
Compound 4 was reported as a limit; the forecaster's own chance of this, stated with the estimate: 75%; the middle value is on the limit's open side.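

Adding a methyl to the ethoxy group does not bring compound 4 into the measurable range of this assay and leaves it at a limit, so the steps from compound 2 and compound 3 to compound 4 cannot be read. Isopropoxy in place of diethylamino gives an at least 2.7-fold higher number from compound 1 to compound 4 (0.44 log units; beyond the scatter) and is a third change away from diethylamino that ends at the limit. Among the compounds shown here, compound 1 remains the only compound here with a number rather than a limit: the limit of > 25000 nM in this assay, at which 3 of the 4 values shown sit.

From the compounds shown here alone, how compound 2, compound 3 and compound 4 rank beyond that limit stays unknown. Also open, going by these compounds, is whether a longer chain on the amine, such as dipropylamino, or a ring amine such as piperidine, would give a lower number than compound 1.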